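Solubility of compound 4 estimated from compound 2

The source may hold more compounds than are shown below. What is called first, only, known or untested is meant among the compounds shown, and "the series" means these compounds.

Measured so far:
compound 1 `Cn1cc(-c2cnc(NCc3c(F)ccc4c3CCO4)c3cn[nH]c(=O)c23)cn1` — 1000 nM
compound 2 `O=C1c2ccccc2CN1c1cnc(NCc2c(F)ccc3c2CCO3)n2cnnc12` — 4000 nM
compound 3 `Cc1ncccc1-c1cnc(NCc2c(F)ccc3c2CCO3)c2n[nH]c(=O)n12` — < 2000 nM

Of the compounds shown here, three sharing the same core have been measured in a physicochemical assay for solubility, read by LC-MS, in phosphate buffer, with a stated time of 24 h, at pH 7.4; on this read-out higher numbers stand for higher solubility and lower numbers for lower solubility. Compound 2 gives 4000 nM, the higher of the two numbers reported; the nearest is compound 1 with 1000 nM, a gap that lies beyond the scatter. Compound 3 returns only a limit of the assay, < 2000 nM, as stated in the limit of < 2000 nM in this assay, at which 1 of the 3 values shown sits. No pair of these compounds differs in a single place, so no measured step is available.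

Compound 4 `O=C(Nc1cnc(NCc2c(F)ccc3c2CCO3)n2cnnc12)c1cccnc1` is yet to be measured. It differs from compound 2 in one place: a group of 9 heavy atoms (6 carbon, 2 nitrogen, 1 oxygen; one six-membered aromatic ring with 1 hetero atom) in place of a group of 10 heavy atoms (8 carbon, 1 nitrogen, 1 oxygen; one five-membered non-aromatic ring with 1 hetero atom, one six-membered aromatic ring of carbon only), on an aromatic carbon. The group that enters carries one hydrogen-bond donor and two acceptors, while the group that leaves carries none and one. Without a measured step to lean on, the expected change is a small one, upward if any, but not beyond the scatter. Compound 4 is therefore estimated at 5000 nM, between 1500 nM and 15000 nM, which means a step of a 1.3-fold higher number from compound 2 to compound 4 (0.10 log units; within the scatter) in this assay.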

Compound 4, solubility: 12000 nM
Beside the measured number, compound 4's estimate is 2.4-fold (0.38 log units) below it; the range from low to high includes it.
By their numbers in this assay, from the lowest: compound 1; then compound 2; then compound 4.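

In this assay, going by these compounds alone, the change at this aromatic carbon of the six-membered aromatic ring with 2 nitrogen gives a 3.0-fold higher number from compound 2 to compound 4 (0.48 log units; beyond the scatter), the first measured step in the set, since no earlier pair differed in one place. It shows that the read-out responds to the group at this position: ((pyridin-3-yl)carbonyl)amino, with its hydrogen-bond donor and single six-membered aromatic ring, gives a higher number than the group with a five-membered non-aromatic ring and a carbon-only aromatic ring. Several features change together in this one step, and nothing measured here points to a cause for it.

The compounds shown do not separate the contribution of the amide hydrogen from that of the pyridine nitrogen. As far as these compounds go, whether a benzoylamino group or an acetylamino group at this position would give a similar number remains open.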